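A few compounds are considered here, and "the series" means these few. Any claim that something is new, unique, unknown or untested is made for them only; others in the source may bear on it.

In a functional assay on the whole organism (strain Wistar) for inhibition, with Rattus norvegicus as the target, read by paw edema, with a stated time of 24 h, at a dose of 100 mg/kg (on this read-out lower numbers stand for less inhibition and higher numbers for more inhibition at the one dose given (going by the name of the read-out)), compound 2 `COc1cc2c(cc1OC)C(CC(=O)Nc1ccc(Br)cc1)CC2` gives 66.7%, the highest of the three numbers on hand. Compound 1 `COc1cc2c(cc1OC)C(CC(=O)Nc1cccc(Cl)c1)CC2` gives 63.3%, and the step of a number 3.4 percentage points higher from compound 1 to compound 2 (within the scatter) lies within the scatter. Compound 3 `COc1cc2c(cc1OC)C(CC(=O)Nc1ccccc1C)CC2` gives 23.3%; the steps of a number 40 percentage points lower from compound 1 to compound 3 (beyond the scatter) and a number 43.4 percentage points lower from compound 2 to compound 3 (beyond the scatter) are both large and beyond the scatter. Compound 4 `COc1cc2c(cc1OC)C(CC(=O)Nc1ccncc1)CC2` is not yet measured; it differs from compound 2 by pyridin-4-yl in place of 4-bromophenyl on an amide-type nitrogen. All measured steps replace the group on the amide-type nitrogen: exchanging 3-chlorophenyl for 4-bromophenyl changed little, while 2-methylphenyl in place of either brought a large fall. Within the data shown here, no measured compound carries pyridin-4-yl, so the direction is uncertain; a moderate fall is expected, as the step of a number 21.7 percentage points lower from compound 2 to compound 4 (beyond the scatter) in this assay. The estimate for compound 4 is 45%, with a range from 20% to 70%.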

Compound 4, a percentage reported as inhibition, in the whole organism at one dose (the size of the read-out at that dose, not a potency): 46.7%
Estimate against measurement, compound 4: 1.7 percentage points below; the measured number falls inside the stated range.
By their numbers in this assay, from the lowest: compound 3; then compound 4; then compounds 1 and 2 (each within the scatter of the next).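

In this assay this position now shows a middle level, with a number 20 percentage points lower from compound 2 to compound 4 (beyond the scatter) and a number 16.6 percentage points lower from compound 1 to compound 4 (beyond the scatter) on one side and a number 23.4 percentage points higher from compound 3 to compound 4 (beyond the scatter) on the other. An aromatic ring with one hetero atom on the amide-type nitrogen thus stays clear of the 2-methylphenyl compound without reaching the 3-chlorophenyl and 4-bromophenyl compounds. No evidence on hand explains this order. Going by these compounds, whether plain phenyl, a phenyl carrying a carboxylic acid, or a saturated amine ring such as piperidinyl on this nitrogen would fall at the same level remains open.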